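A Dichlorophenyl Swap Among Solubility Limits

This account rests on a few compounds, and the source may have more. Where it says the series, first, only, none or still open, it means among the compounds named here.

In a physicochemical assay for solubility, read by spectrophotometry (a higher number here means a more soluble compound, a lower number a less soluble compound), compound 3 `O=C(Oc1ccc(Cl)cc1C(=O)Nc1ccc(C(F)(F)F)cc1)c1cnc(Cl)cn1` gives < 100000 nM, which is a limit and not a measured number. Compound 1 `O=C(Nc1ccc(C(F)(F)F)cc1)c1cc(Cl)ccc1O` gives < 100000 nM, also a limit. Compound 2 `O=C(c1ccccc1)c1ccc(NC(=O)c2cc(Cl)ccc2O)cc1` gives < 50000 nM, again a limit. None of the three compounds therefore has an exact value, and compound 3 cannot be ranked against the other two.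

Compound 4 `O=C(Oc1ccc(Cl)cc1C(=O)Nc1ccc(Cl)c(Cl)c1)c1cnc(Cl)cn1` has 3,4-dichlorophenyl in place of 4-(trifluoromethyl)phenyl on an amide-type nitrogen.

Two measured steps offer some guidance. Benzoyl in place of trifluoromethyl on an aromatic carbon gives a step that the two limits leave unreadable from compound 1 to compound 2. Putting an acyl group on the oxygen that otherwise carries hydrogen gives a step that the two limits leave unreadable from compound 1 to compound 3. Neither step has a readable size, and neither is the same change as the one made here. They therefore point in no direction, and no shift beyond the usual scatter can be predicted in this assay. The expected change is a step that the limit leaves unreadable from compound 3 to compound 4, a working figure with little behind it. The estimated solubility of compound 4 is 25000 nM, with an expected range from 4000 nM to 100000 nM. A further limit instead of a number is the likeliest report.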

Compound 4, solubility: < 100000 nM
Compound 4 gave a limit, no number (the forecaster's own chance of this, stated with the estimate: 85%); the middle value does not contradict the limit.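

Compound 3 and compound 4 both report only a limit in this assay, not a number, so the step between them cannot be read. The compounds shown leave open how soluble compound 1, compound 2, compound 3 and compound 4 actually are, and whether 3,4-dichlorophenyl in place of 4-(trifluoromethyl)phenyl shifts the read-out at all.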